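This account rests on a few compounds, and the source may have more. Where it says the series, first, only, none or still open, it means among the compounds named here.

Three amides that share one core have been characterised in an in vitro assay on BTI-TN-5B1-4 cells for inhibition of Amine oxidase [flavin-containing] B (Homo sapiens), read by fluorescence; on this read-out higher numbers stand for weaker inhibition and lower numbers for stronger inhibition. Compound 1, `O=C(Nc1ccccc1Cc1ccccc1)c1cc2ccccc2oc1=O`, gives 910 nM in this assay. Compound 2, `Cc1cccc(NC(=O)c2cc3ccccc3oc2=O)c1`, gives 600 nM in this assay. Compound 3, `CC(C)c1ccc(NC(=O)c2cc3ccccc3oc2=O)cc1`, gives 650 nM in this assay. The three numbers lie close together: the number for compound 3 sits among those of compound 1 and compound 2, and its distance to each of them stays within the usual scatter of repeated measurements, so none of the three can be set apart from the others on these data.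

The next compound, compound 4, `CS(=O)(=O)c1ccc(NC(=O)c2cc3ccccc3oc2=O)cc1`, has not been measured. Relative to compound 3 the change is methylsulfonyl in place of isopropyl on an aromatic carbon. Among the compounds with values here, no pair of measured compounds differs in this way, so there is no measured step on which to rest the expectation; the only guide is how narrow the span of the three known numbers is. The step from compound 3 to compound 4 is expected to be a 1.8-fold higher number from compound 3 to compound 4 (0.27 log units; within the scatter), that is, a modest move toward weaker inhibition that may not exceed the scatter. The estimate for compound 4 in this assay is 1200 nM, expected to fall between 400 nM and 4000 nM.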

Compound 4, half-maximal inhibitory concentration: 1.4 nM
Compound 4: middle estimate off by 860-fold (2.93 log units), on the high side; the whole stated range lies above it.
By their numbers in this assay, from the lowest: compound 4; then compounds 2, 3 and 1 (each within the scatter of the next).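

In this assay, the aromatic carbon para to a large group proves to be a place where the substituent can decide the outcome: methylsulfonyl in place of isopropyl gives a 460-fold lower number from compound 3 to compound 4 (2.67 log units; beyond the scatter), a large move toward stronger inhibition from a single change. The narrow span of the earlier numbers therefore gave no measure of how much this position can do, and compound 4 now stands apart from the other amides on the shared core. The change replaces a group with no hydrogen-bond acceptors by one with two and brings in sulfur and oxygen, but no available measurement ties the step to any of these differences or otherwise accounts for it.

The compounds shown leave open whether the step belongs to methylsulfonyl alone or would also appear with a nitrile, a sulfonamide or an acetyl group on the same carbon. They also leave open whether methylsulfonyl would keep this effect on another carbon of that ring, and whether a smaller group such as methyl at this position would behave like isopropyl.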